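Cyclohexyl for 1-propylbutyl on the ring nitrogen

The compounds below may be only part of what the source reports. "The series", "measured", "known", "first", "only" and "open" are said of these compounds alone.

For the measured compounds named here, the three measured members share one core: compound 1 `CC(C)c1onc(-c2c(Cl)cccc2Cl)c1COc1ccc(-c2nc3ccc(C(=O)O)cc3n2CC2CCCCC2)c(F)c1`, compound 2 `CCCC(CCC)n1c(-c2ccc(OCc3c(-c4c(Cl)cccc4Cl)noc3C(C)C)cc2)nc2ccc(C(=O)O)cc21` and compound 3 `CCC(CC)n1c(-c2ccc(OCc3c(-c4c(Cl)cccc4Cl)noc3C(C)C)cc2Cl)nc2ccc(C(=O)O)cc21`. In an assay on HEK-293T cells for antagonist activity at vitamin D3 receptor (Homo sapiens), read by a luciferase reporter, with a stated time of 24 h (a higher number here means a weaker inhibitor, a lower number a stronger inhibitor), compound 1 gives 840 nM. Compound 3 gives 1010 nM in this assay, a value that sits within the scatter of compound 1. Compound 2 is reported in this assay only as a limit, > 10000 nM, and so has no number of its own; see (the limit of > 10000 nM in this assay, at which 1 of the 3 values shown sits). Compound 2 therefore stands at the weak end of what is shown, the only member without a measured number.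

Compound 4 `CC(C)c1onc(-c2c(Cl)cccc2Cl)c1COc1ccc(-c2nc3ccc(C(=O)O)cc3n2C2CCCCC2)cc1` differs from compound 2 by cyclohexyl in place of 1-propylbutyl on an aromatic nitrogen. Going by the values given here, no measured pair differs in one place only, so no step size can be copied. Compound 1 and compound 3 both carry groups of fewer or equal heavy atoms on that nitrogen and both give numbers, while compound 2 with its 1-propylbutyl does not; compound 4 also lacks the halogen on the central ring that compound 1 and compound 3 carry. Against the limit of compound 2, a gain beyond the scatter is expected, estimated as an at least 2.5-fold lower number from compound 2 to compound 4 (0.39 log units; beyond the scatter), with wide uncertainty. Compound 4 is expected at 4000 nM, in the range 1000 nM to 15000 nM.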

Compound 4, half-maximal inhibitory concentration: 1450 nM
Estimate against measurement, compound 4: 2.8-fold (0.44 log units) above, and the stated range covers the measured number.
By their numbers in this assay, from the lowest: compounds 1, 3 and 4 (each within the scatter of the next). At a limit, above all of these: compound 2.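

For the compounds shown here, this is the first pair that differs in one place only, and it gives a step at the aromatic nitrogen in this assay: cyclohexyl in place of 1-propylbutyl gives an at least 6.8-fold lower number from compound 2 to compound 4 (0.83 log units; beyond the scatter). The change swaps an open chain for one six-membered non-aromatic ring of carbon only, with one heavy atom fewer and no change in hydrogen-bond donors, hydrogen-bond acceptors or net charge, and this single exchange is enough to bring a measured number out of the limit. Going by these compounds, compound 2 stands only at a limit, so the step is a lower bound and its full size stays unknown: the limit of > 10000 nM in this assay, at which 1 of the 4 values shown sits.

On these data alone, whether the step follows from the ring itself or from losing the 1-propylbutyl chain stays open, and cyclopentyl or a straight hexyl chain on the same nitrogen would help to separate the two. Also open, as far as these compounds go, is how a piperidine ring with its amine would fare at this position, and compound 1 and compound 3 each differ from compound 4 in more than one place, so neither gives a clean step to it.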